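Chlorobenzyl positional isomers on the hydrazone series

A few compounds are considered here, and "the series" means these few. Any claim that something is new, unique, unknown or untested is made for them only; others in the source may bear on it.

Measured compounds:
- compound 1 `CCCSc1nc(N/N=C(\C)c2ccccc2O)c2nnn(Cc3ccc(Cl)cc3)c2n1`: 7100 nM
- compound 2 `CCCSc1nc(N/N=C(\C)c2ccc(OC)cc2)c2nnn(Cc3ccccc3)c2n1`: 44300 nM

In a functional assay on MGC-803 cells (Homo sapiens) for antiproliferative activity, read by MTT assay, with a stated time of 72 h (a higher number here means a weaker inhibitor, a lower number a stronger inhibitor), compound 1 gives 7100 nM and stands lowest of the two numbers recorded. Compound 2 differs from compound 1 in two places at once, so the gap between them cannot be assigned to a single change; in this assay compound 2 gives 44300 nM, a gap beyond the scatter.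

Compound 3 `CCCSc1nc(N/N=C(\C)c2ccccc2O)c2nnn(Cc3ccccc3Cl)c2n1` has not been measured. It differs from compound 1 in a single place: 2-chlorophenyl in place of 4-chlorophenyl on a saturated chain carbon bound to an aromatic nitrogen. Going by the values given here, no step between measured compounds isolates this change, so there is no direct precedent for its size. A move of a chlorine within the same benzyl ring on a shared core is expected to give a small step, likely within the scatter or only just beyond it, with no clear direction from the data shown. The estimated step from compound 1 to compound 3 is a 1.3-fold higher number from compound 1 to compound 3 (0.10 log units; within the scatter). In this assay compound 3 is expected to give about 9000 nM, with a range from 3000 nM to 30000 nM.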

Compound 3, half-maximal inhibitory concentration: 35000 nM
For compound 3 the middle estimate is 3.9-fold (0.59 log units) below the measured one, outside the stated range (above it).
By their numbers in this assay, from the lowest: compound 1; then compounds 3 and 2 (each within the scatter of the next).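

In this assay, where the chlorine sits on the benzyl group matters: exchanging 4-chlorobenzyl for 2-chlorobenzyl, with the same atoms joined differently, gives a step beyond the scatter (a 4.9-fold higher number from compound 1 to compound 3 (0.69 log units; beyond the scatter)). Going by these compounds alone, this is the first single-place comparison, and it favours 4-chlorobenzyl over 2-chlorobenzyl, a preference that so far rests on this one pair and this one hydrazone. No measurement at hand bears on the origin of the step, which stays unassigned.

Within the data shown here, still open is whether the same preference holds on another hydrazone of the series, such as the one carrying the methoxy group of compound 2, or whether this gap belongs to the hydrazone of compound 1 alone. Also open, from the compounds shown here alone, is how the two chlorobenzyl isomers compare with the plain benzyl group on the hydrazone of compound 1, and whether a bromine, a methoxy group or an amine in place of the chlorine would follow the same order between the two ring positions.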